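The compounds below may be only part of what the source reports. "The series", "measured", "known", "first", "only" and "open" are said of these compounds alone.

Two compounds share a common core that carries a nitrile and a phenyl ring, and they differ in the group attached to the sulfur. Compound 1 `C#CCSc1nc(Nc2ccccc2Cl)c(C#N)c(-c2ccccc2)n1` bears a short propargyl chain there. In a functional assay on MCF7 cells (Homo sapiens) for inhibition, read by MTT assay, with a stated time of 72 h (a higher number here means a weaker inhibitor, a lower number a stronger inhibitor), compound 1 gives 24200 nM. Compound 2 `N#Cc1c(Nc2ccccc2Cl)nc(SCc2cn(Cc3ccccc3Cl)nn2)nc1-c1ccccc1` instead carries a triazole linked to a chlorobenzyl group. In this assay compound 2 gives 1950 nM, the lowest of the two numbers shown, and the gap to compound 1 lies beyond the usual scatter.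

Compound 3 `Cc1cccc(Nc2nc(SCc3cn(Cc4ccccc4Cl)nn3)nc(-c3ccccc3)c2C#N)c1` keeps everything of compound 2 except one change: 3-methylphenyl in place of 2-chlorophenyl on a nitrogen on an aromatic ring. Going by the values given here, no measured pair shows this exchange, so the data give no direct guide to its effect. The step of a 1.3-fold higher number from compound 2 to compound 3 (0.11 log units; within the scatter) is expected to be small, quite possibly none beyond the scatter. Compound 3 is therefore estimated at 2500 nM, with a plausible range from 800 nM to 8000 nM.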

Compound 3, half-maximal inhibitory concentration: 19600 nM
For compound 3 the middle estimate is 7.8-fold (0.89 log units) below the measured one; measured number above the stated range.
By their numbers in this assay, from the lowest: compound 2; then compounds 3 and 1 (each within the scatter of the next).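

In this assay, putting 3-methylphenyl in place of 2-chlorophenyl on a nitrogen on an aromatic ring gives a 10-fold higher number from compound 2 to compound 3 (1.00 log units; beyond the scatter). Going by these compounds alone, the earlier compounds differed only in the group on the sulfur, so this is the first sign that the aryl group on the nitrogen also matters to the number. Both groups are six-membered aromatic rings of carbon only, so an exchange that keeps that ring type can still move the result beyond the scatter. Nothing measured here explains the step.

This single exchange replaces chlorine with methyl and also changes the printed ring position, so the two changes cannot be separated. The 3-chlorophenyl and 2-methylphenyl groups, which would pull these two changes apart, are not among the compounds shown.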